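A few compounds are considered here, and "the series" means these few. Any claim that something is new, unique, unknown or untested is made for them only; others in the source may bear on it.

Measured to date:
compound 1 `O=C(NCCCCc1ccccc1)n1c(-c2ccccc2)coc1=O` — in an assay on isolated protein for inhibition of acid ceramidase (Homo sapiens), read by LC-MS, with a stated time of 1 h (a higher number here means a weaker inhibitor, a lower number a stronger inhibitor), compound 1 gives 70 nM
compound 2 `CCCCCNC(=O)n1cc(-c2ccccc2)oc1=O` — compound 2 gives 39 nM
compound 3 `COc1ccccc1-c1cn(C(=O)NCCCCc2ccccc2)c(=O)o1` — compound 3 gives 177 nM

Compound 3 carries the highest of the three numbers in this assay; its nearest neighbour, compound 1, and its furthest, compound 2, both sit beyond the scatter from it. No pair among these three differs in a single place, so no measured step is available to anchor the next change.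

Compound 4 `O=C(NCCCCc1ccccc1)n1cc(-c2cnccn2)oc1=O` is the next entry: pyrazin-2-yl in place of 2-methoxyphenyl on an aromatic carbon. Nothing measured here shows what exchanging one six-membered aromatic ring for another does on this core, so the direction is open; a step of modest size either way is as plausible as none beyond the scatter. On balance compound 4 is expected to land near the middle of the measured numbers, estimated at 100 nM (range 30 nM to 400 nM), which would mean an expected step of a 1.8-fold lower number from compound 3 to compound 4 (0.25 log units; within the scatter).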

Compound 4, half-maximal inhibitory concentration: 32 nM
The estimate for compound 4 lay 3.1-fold (0.49 log units) above the measured number; measured number inside the range.
By their numbers in this assay, from the lowest: compounds 4, 2 and 1 (each within the scatter of the next, the first and the last beyond it); then compound 3.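

Pyrazin-2-yl in place of 2-methoxyphenyl, on the aromatic carbon next to the ring oxygen, gives a 5.5-fold lower number from compound 3 to compound 4 (0.74 log units; beyond the scatter) in this assay. This position therefore responds to the exchange of one six-membered aromatic ring for another, and a ring with 2 hetero atoms is accepted there. Nothing available explains the size of this step.

This single step does not separate the departure of the methoxy group from the entry of the ring nitrogens. A pyridin-2-yl group at this position, with all else as in compound 4, would help to separate them.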